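A few compounds are considered here, and "the series" means these few. Any claim that something is new, unique, unknown or untested is made for them only; others in the source may bear on it.

Measured so far in a functional assay on ileum for antagonist activity at muscarinic acetylcholine receptor M3 (Cavia porcellus); a higher number here means a more potent compound, by a factor of ten per unit of this negative logarithm, a lower number a less potent compound:
Compound 1 `C[C@H]1O[C@@H]([C@@H]2CCCN2C)C[S@+]1[O-]` gives < 5, a limit of this assay.
Compound 2 `C[C@@H]1O[C@H]([C@@H]2CCCN2C)C[S@@+]1[O-]` gives < 5, a limit of this assay.

For the measured compounds named here, compound 2 stands only at a limit in this assay, and the one other value shown is also a limit. Going by the values given here, the single measured step, a step that the two limits leave unreadable from compound 1 to compound 2, cannot be read because of the limit of < 5 in this assay, at which 2 of the 2 values shown sit; it is a change of three stereo elements at once, two saturated ring carbons and the sulfur, and the fact that compounds 1 and 2 differ only in the configuration as drawn is all that ties the two compounds together.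

Compound 3 `C[C@@H]1O[C@H]([C@@H]2CCCN2C)C[S@+]1[O-]` is the next member. Relative to compound 2 the change is the two compounds have the same atoms and bonds and differ only in configuration as drawn: 1 of 4 stereo elements differ; a stereocentre at a sulfur is drawn R in compound 2 and S in compound 3. Among the compounds with values here, the one measured step that involves the sulfur configuration, from compound 1 to compound 2, also moved two ring carbons and gave no readable size, so nothing here shows that inverting the sulfur alone carries the potency out of the region of the limit. In this assay no step beyond the scatter is therefore expected for compound 3; the estimated step that the limit leaves unreadable from compound 2 to compound 3 is taken as none. Compound 3 is expected to show 4.5, with a range from 3.5 to 5.5, and most likely again only a limit.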

Compound 3, negative logarithm of the antagonist equilibrium constant: < 5
Compound 3 ended at the assay's limit (the forecaster's own chance of this, stated with the estimate: 75%); the middle value is on the limit's open side.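

The steps from compound 1 to compound 2, from compound 2 to compound 3 and from compound 1 to compound 3 cannot be read in this assay, because all three compounds sit at one limit: the limit of < 5 in this assay, at which 3 of the 3 values shown sit.

As far as these compounds go, whether inverting the sulfur or the two saturated ring carbons changes potency at all, and how far each compound lies from that limit, remains open.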